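The source may hold more compounds than are shown below. What is called first, only, known or untested is meant among the compounds shown, and "the series" means these compounds.

Compound 1, `COc1cc(-c2cc(/C=C/C(=O)c3ccc(N)cc3)[nH]n2)cc(OC)c1OC`, was tested in a functional assay on UO-31 cells (Homo sapiens) for inhibition, read by sulforhodamine B assay, with a stated time of 48 h (on this read-out higher numbers stand for weaker inhibition of growth and lower numbers for stronger inhibition of growth), and gives 2860 nM. On this read-out compound 1 stands as the higher of the two numbers, the other belonging to compound 2, `COc1ccc(-c2cc(/C=C/C(=O)c3ccc(OC)c(OC)c3)[nH]n2)cc1`, which in this assay gives 2440 nM; the two lie within the scatter of each other. Compound 3, `COc1cc(-c2cc(/C=C/C(=O)c3ccc(Cl)c(Cl)c3)[nH]n2)cc(OC)c1OC`, has not yet been measured and differs from compound 1 by 3,4-dichlorophenyl in place of 4-aminophenyl on a carbonyl carbon. Going by the values given here, no measured pair shows this change, so the expected step of a 1.4-fold lower number from compound 1 to compound 3 (0.16 log units; within the scatter) is modest and not clearly beyond the scatter. Compound 3 is estimated at 2000 nM, within a range from 700 nM to 6000 nM.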

Compound 3, concentration for total growth inhibition: > 100000 nM
Compound 3 gave a limit, no number (the forecaster's own chance of this, stated with the estimate: 5%); middle value at least 50-fold (1.69 log units) from the limit.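

Replacing 4-aminophenyl with 3,4-dichlorophenyl on a carbonyl carbon gives an at least 34-fold higher number from compound 1 to compound 3 (1.54 log units; beyond the scatter) in this assay, so on the core of compound 1 the group at this position can decide whether growth inhibition is seen in the tested range. Compound 3 gives a limit and not a number: the limit of > 100000 nM in this assay, at which 1 of the 3 values shown sits.

The compounds shown leave open whether the step follows the loss of the amine or the entry of the chlorine atoms. A plain phenyl, a 4-chlorophenyl or a 4-hydroxyphenyl at this position would help to separate the two.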